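Benzamide aryl variation in a pyrazolylpropyl amide series

The source may hold more compounds than are shown below. What is called first, only, known or untested is meant among the compounds shown, and "the series" means these compounds.

Compound 1 `CC(O)c1cccc(C(=O)N[C@@H](C)Cn2ccc(-c3ccc(C#N)c(Cl)c3)n2)c1` is the reference point of this pair of notes. Going by the values given here, in a functional assay on LNCaP cells (Homo sapiens) for antiproliferative activity, read by CCK-8 assay, with a stated time of 6 days (on this read-out lower numbers stand for stronger inhibition and higher numbers for weaker inhibition), compound 1 gives 2280 nM, the highest of the two numbers measured so far. Among the compounds with values here, its nearest neighbour, compound 2 `C[C@@H](Cn1ccc(-c2ccc(C#N)c(Cl)c2)n1)NC(=O)c1cccc(OCC(O)CO)c1`, gives 740 nM in this assay, and the only measured step, a 3.1-fold lower number from compound 1 to compound 2 (0.49 log units; beyond the scatter), shows that exchanging the substituent on the benzamide ring moves the number by a modest but real amount.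

Compound 3 `C[C@@H](Cn1ccc(-c2ccc(C#N)c(Cl)c2)n1)NC(=O)c1ccccc1F` differs from compound 1 by 2-fluorophenyl in place of 3-(1-hydroxyethyl)phenyl on a carbonyl carbon. The step from compound 1 to compound 2 bears on this only in touching the same ring, so the direction is open. The expected step is a 1.3-fold lower number from compound 1 to compound 3 (0.10 log units; within the scatter). For compound 3 the estimate in this assay is 1800 nM, with a range from 500 nM to 6500 nM.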

Compound 3, half-maximal inhibitory concentration: 1810 nM
Compound 3: middle estimate off by 1.0-fold (0.00 log units), on the low side, and the stated range covers the measured number.
By their numbers in this assay, from the lowest: compound 2; then compounds 3 and 1 (each within the scatter of the next).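

In this assay, 2-fluorophenyl in place of 3-(1-hydroxyethyl)phenyl on the carbonyl carbon gives a 1.3-fold lower number from compound 1 to compound 3 (0.10 log units; within the scatter), so this exchange does not separate compound 1 from compound 3. The entering group has 0 hydrogen-bond donors and 0 hydrogen-bond acceptors, against 1 of each in the group that leaves, so the hydroxyl of compound 1 is not needed for a value at this level. No independent data on hand bear on this result.

The change alters both the substituent and its printed ring position, and the compounds shown do not separate these two variables. Also open, on these data alone, is whether an aminomethyl group or a carboxylic acid on the benzamide ring would move the number beyond the scatter.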